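This account rests on a few compounds, and the source may have more. Where it says the series, first, only, none or still open, it means among the compounds named here.

Three esters of the same acid part have been tested in a functional assay on NCI-H157 cells (Homo sapiens) for cytotoxicity, read by resazurin assay, with a stated time of 72 h; on this read-out higher numbers stand for weaker inhibition and lower numbers for stronger inhibition. Compound 1, `COc1cc(/C=C/C(=O)Oc2ccc(OCc3c(-c4ccccc4)no[n+]3[O-])cc2)ccc1O`, carries a phenyl ester and gives 43100 nM. Compound 2, `COc1cc(/C=C/C(=O)OC/C=C/CO[N+](=O)[O-])ccc1O`, carries a chain ester bearing a nitrate and gives 4290 nM. Compound 3, `COc1cc(/C=C/C(=O)OCc2cccc(OCc3c(-c4ccccc4)no[n+]3[O-])c2)ccc1O`, reaches only a limit of the assay, > 50000 nM, as noted in the limit of > 50000 nM in this assay, at which 1 of the 3 values shown sits.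

Among the two numbers, compound 2 stands lowest; compound 1 is the nearest, with a number beyond the usual scatter higher. No pair of these compounds differs in a single place, so none of the gaps can be read as a single step.

Compound 4, `COc1cc(/C=C/C(=O)OCCCO[N+](=O)[O-])ccc1O`, is not yet measured. It differs from compound 2 by the change (a group of 6 heavy atoms (2 carbon, 1 nitrogen, 3 oxygen; no ring) in place of a group of 7 heavy atoms (3 carbon, 1 nitrogen, 3 oxygen; no ring), on a saturated chain carbon bound to an oxygen next to a carbonyl group).

Among the compounds with values here, since no measured step of this kind is available, the expectation rests on the chain ester of compound 2 alone. The step from compound 2 to compound 4 is expected to be small, likely within the scatter or at most slightly toward weaker inhibition, a 1.5-fold higher number from compound 2 to compound 4 (0.18 log units; within the scatter). Compound 4 is therefore expected to give about 6500 nM in this assay, with a range from 2000 nM to 20000 nM.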

Compound 4, half-maximal inhibitory concentration: 20500 nM
Beside the measured number, compound 4's estimate is 3.2-fold (0.50 log units) below it, outside the stated range (above it).
By their numbers in this assay, from the lowest: compound 2; then compound 4; then compound 1. At a limit, above all of these: compound 3.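

Within the data shown here, this is the first single-place comparison in the set, and it shows that the group on a saturated chain carbon bound to an oxygen next to a carbonyl group is not indifferent in this assay: placing 2-(nitrooxy)ethyl there gives a 4.8-fold higher number from compound 2 to compound 4 (0.68 log units; beyond the scatter). The step occurs although the leaving and entering groups have the same counts of hydrogen-bond donors and acceptors and neither carries a net charge; their computed differences lie in the carbon count and the number of double bonds. Nothing measured here gives a cause for the step.

Whether chain length or the double bond accounts for the gap stays open, and a saturated chain of the same length as in compound 2 would separate the two. A plain hydroxyl in place of the nitrate would test what that group contributes at this position.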